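The compounds below may be only part of what the source reports. "The series", "measured", "known", "first", "only" and "open" are said of these compounds alone.

Measured compounds:
compound 1, `O=C(/C=C/c1ccc2c(c1)B(O)OC2)c1cccs1`, 4600 nM
compound 2, `Cc1ccc(C(=O)/C=C/c2ccc3c(c2)B(O)OC3)cc1C`, 5300 nM

Of the compounds shown here, two share the core and have been measured in a functional assay on MDA-MB-231 cells (Homo sapiens) for cytotoxicity, read by MTT assay, with a stated time of 48 h; on this read-out higher numbers stand for weaker inhibition and lower numbers for stronger inhibition. Compound 1 gives 4600 nM, the lowest of the two numbers, while compound 2 gives 5300 nM; the two values lie within the scatter of each other, so neither can be set above the other.

The unmeasured compound 3, `O=C(/C=C/c1ccc2c(c1)B(O)OC2)c1cccc(O)c1`, is reached from compound 1 by one change: 3-hydroxyphenyl in place of thiophen-2-yl on a carbonyl carbon. Among the compounds with values here, no pair of measured compounds differs at the same place, so the step to be expected in this assay has no measured counterpart here. What the two measured values show is that a change of the aryl group on the carbonyl carbon, from compound 1 to compound 2, moved the number by less than the scatter. On that basis the expectation for compound 3 is a step from compound 1 of a 1.1-fold higher number from compound 1 to compound 3 (0.04 log units; within the scatter), no larger than the scatter in either direction. Compound 3 is therefore estimated at 5000 nM, with a range from 2000 nM to 12000 nM.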

Compound 3, half-maximal inhibitory concentration: 2700 nM
Beside the measured number, compound 3's estimate is 1.9-fold (0.27 log units) above it, within the range that was stated.
By their numbers in this assay, from the lowest: compounds 3, 1 and 2 (each within the scatter of the next).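

In this assay, putting 3-hydroxyphenyl in place of thiophen-2-yl on the carbonyl carbon gives a 1.7-fold lower number from compound 1 to compound 3 (0.23 log units; within the scatter), so this place now has a step read directly between two compounds that differ only there. The change replaces a five-membered aromatic ring holding sulfur with a six-membered aromatic ring of carbon only and also brings in a hydrogen-bond donor, yet together these differences leave the number within the scatter, and this single step cannot separate the ring from the donor. Nothing available on these compounds gives a reason for this result.

The compounds shown leave open whether plain phenyl on the carbonyl carbon would give a number like that of compound 3, which would help show whether the hydroxyl group matters at all. They also leave open whether an aminophenyl group or a carboxylic acid at this place would move the number beyond the scatter, and whether any change elsewhere on the shared core would do so.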